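The source may hold more compounds than are shown below. What is called first, only, known or untested is meant among the compounds shown, and "the series" means these compounds.

Compound 1 `COc1ccc(-c2nc(CNc3ccc(C(=O)NO)cc3)n(-c3ccccc3)n2)cc1`: 77.6%
Compound 2 `O=C(NO)c1ccc(NCc2nc(-c3ccc(Cl)cc3)nn2-c2ccccc2)cc1`: 67.2%

Both numbers come from an assay on Sf9 cells for inhibition of protein deacetylase HDAC6 (Homo sapiens), read by fluorescence, with a stated time of 40 min, tested at 100 nM; a lower number here means less inhibition, a higher number more inhibition at the concentration tested (going by the name of the read-out). Compound 2 stands lowest of the two. Among the compounds with values here, the single step measured so far is a number 10.4 percentage points lower from compound 1 to compound 2 (beyond the scatter), a modest move. Compound 3 `Cc1ccc(-c2nc(CNc3ccc(C(=O)NO)cc3)n(-c3ccccc3)n2)s1` differs from compound 2 by 5-methylthiophen-2-yl in place of 4-chlorophenyl on an aromatic carbon. Within the data shown here, no measured step exchanges one ring for another, so the known step does not bear directly on this change and offers no direction. The step from compound 2 to compound 3 is therefore expected to be a number 0.8 percentage points higher from compound 2 to compound 3 (within the scatter), none beyond the scatter. Compound 3 is estimated at 68%, within 50% to 85%.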

Compound 3, a percentage reported as inhibition, at one concentration (the size of the read-out at that concentration, not a potency): 79.7%
The estimate for compound 3 lay 11.7 percentage points below the measured number, within the range that was stated.
By their numbers in this assay, from the lowest: compound 2; then compounds 1 and 3 (each within the scatter of the next).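

In this assay, this position on the five-membered aromatic ring with 3 nitrogen accepts a five-membered ring in place of a six-membered one: 5-methylthiophen-2-yl replacing 4-chlorophenyl gives a number 12.5 percentage points higher from compound 2 to compound 3 (beyond the scatter) and replacing 4-methoxyphenyl gives a number 2.1 percentage points higher from compound 1 to compound 3 (within the scatter). Among these three groups, only 4-chlorophenyl stands apart, as compound 2 lies beyond the scatter of both others. No measured evidence accounts for this difference.

From the compounds shown here alone, what the methyl group on the thiophene contributes remains open. So does how an unsubstituted thiophen-2-yl, a pyridin-3-yl or a 4-aminophenyl group would behave at this position.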